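The source may report more compounds than this note shows. Statements on the series, on what has been measured and on what is new or still open speak of the compounds shown alone.

Three compounds have been tested in a functional assay on MCF7 cells (Homo sapiens) for inhibition, read by sulforhodamine B assay; on this read-out lower numbers stand for stronger inhibition and higher numbers for weaker inhibition:

compound 1 `O=C1C(Nc2ccccc2F)=CC(=O)c2c1nc1n2[C@H]2OC[C@@H](O)[C@H]2OC1`: > 4000 nM
compound 2 `O=C1C=C(N2CCC2)C(=O)c2c1nc1n2[C@H]2OC[C@@H](O)[C@H]2OC1`: > 16000 nM
compound 3 `O=C1C(NC2CCCC2)=CC(=O)c2c1nc1n2[C@H]2OC[C@@H](O)[C@H]2OC1`: > 16000 nM

All three entries are limits of the assay and not numbers. Compound 3 has only its limit of > 16000 nM, so its place among the others cannot be ranked. The picture so far consists of the limit of > 16000 nM in this assay, at which 2 of the 3 values shown sit. The remaining entry is the limit of > 4000 nM in this assay, at which 1 of the 3 values shown sits.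

The next compound, compound 4 `Cc1ccc(NC2=CC(=O)c3c(nc4n3[C@H]3OC[C@@H](O)[C@H]3OC4)C2=O)cc1`, has not yet been measured. It differs from compound 3 by 4-methylphenyl in place of cyclopentyl on an amine nitrogen. Going by the values given here, the only measured step that bears on this change is a step that the two limits leave unreadable from compound 1 to compound 3. That step gives neither a size nor a direction to carry over. Compound 1 carries 2-fluorophenyl on its amine nitrogen and has the limit > 4000 nM. Among the compounds with values here, no measured compound in this assay has yet given a number, so compound 4 is expected to remain weak and may well return only a limit. The expected step is an at least 1.3-fold lower number from compound 3 to compound 4 (0.12 log units; that floor lies within the scatter), an estimate that rests on limits alone. For compound 4 the estimated value is 12000 nM, with an expected range from 4000 nM to 32000 nM.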

Compound 4, half-maximal inhibitory concentration: > 4000 nM
Compound 4: only a limit was reported; the forecaster's own chance of this, stated with the estimate: 70%; the middle value does not contradict the limit.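

Compound 4 gives only a limit in this assay, as do compound 1 and compound 3, so neither the step from compound 3 to compound 4 nor the step from compound 1 to compound 4 can be read. The compounds shown leave open whether any group on the amine nitrogen of the shared core gives a measurable number. Compound 4 joins compound 1 here: the limit of > 4000 nM in this assay, at which 2 of the 4 values shown sit.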